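Cyclobutyl in place of isobutyl on a sulfonamide nitrogen

A few compounds are considered here, and "the series" means these few. Any claim that something is new, unique, unknown or untested is made for them only; others in the source may bear on it.

Among the compounds with values here, in a physicochemical assay for lipophilicity, at pH 7.4 (on this read-out lower numbers stand for lower lipophilicity and higher numbers for higher lipophilicity), compound 1 `CCc1ccc(N(CC2CC2)S(=O)(=O)c2ccc3c(c2)C(=O)CC(C2CCOCC2)O3)cc1` gives 3.77 and compound 2 `CCc1ccc(N(CC(C)C)S(=O)(=O)c2ccc3c(c2)C(=O)CC(C2CCOCC2)O3)cc1` gives 4.21 as the higher of the two numbers so far. Compound 3 `CCc1ccc(N(C2CCC2)S(=O)(=O)c2ccc3c(c2)C(=O)CC(C2CCOCC2)O3)cc1` shares their core and is still unmeasured. It carries cyclobutyl in place of isobutyl on a sulfonamide nitrogen so a group with no ring gives way to a group with one.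

Within the data shown here, only one measured step bears on this: a number 0.44 log units higher from compound 1 to compound 2 (beyond the scatter) for isopropyl in place of cyclopropyl on a saturated chain carbon bound to a sulfonamide nitrogen. That step is modest but beyond the usual scatter. It took a ring away, whereas the change to compound 3 brings one in. It also happened at a different place, so it is only a rough guide.

Compound 1, with its ring, stands at 3.77 and so a number lower than that of compound 2 is expected in this assay by a step of similar size. The expected step is a number 0.36 log units lower from compound 2 to compound 3 (beyond the scatter) in the downward direction. For compound 3 the estimate is 3.85 and the expected range runs from 3.45 to 4.25 around it.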

Compound 3, distribution coefficient: 3.78
Compound 3: the middle estimate sits 0.07 log units above what was measured; measured number inside the range.
By their numbers in this assay, from the lowest: compounds 1 and 3 (each within the scatter of the next); then compound 2.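

Cyclobutyl in place of isobutyl on the sulfonamide nitrogen leaves the heavy-atom count as it stands and adds one ring, and this swap gives a number 0.43 log units lower from compound 2 to compound 3 (beyond the scatter) in this assay. Within the data shown here, this is the first step at this position in which a ring is the only difference counted between the two groups, so the number can shift without any change in size as counted by heavy atoms. Cyclobutyl in place of cyclopropylmethyl gives a number 0.01 log units higher from compound 1 to compound 3 (within the scatter), so in this assay these two ring-bearing groups cannot be told apart, and among these compounds the ringless isobutyl group of compound 2 stands apart from both, with no compound shown going against that.

From the compounds shown here alone, it remains open whether a larger ring such as cyclohexyl, a longer open chain such as pentyl, or a group carrying an amine on this nitrogen would fit the same picture. Nothing shown here explains why a ring at this position goes with a different number.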